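The compounds below may be only part of what the source reports. "The series", "measured", "known", "first", "only" and "open" are said of these compounds alone.

Three analogues of the shared core have been run in a functional assay on MCF7 cells (Homo sapiens) for inhibition, read by XTT assay, with a stated time of 48 h; a lower number here means a stronger inhibitor, a higher number a weaker inhibitor. Compound 1 `COc1ccc(C(=O)/C(=C/c2ccccc2Cl)COC(=O)c2ccccc2)cc1` gives 9000 nM. Compound 2 `COc1ccc(C(=O)/C(=C/C2CCCCC2)CCOC(C)=O)cc1` gives only a limit of the assay, > 100000 nM. Compound 3 `C=C(C(=O)c1ccc(OC)cc1)C(OC(C)=O)c1ccccc1F` gives 18000 nM, the higher of the two numbers, with compound 1 as its nearest neighbour and the gap between them within the scatter. Compound 4 `C=C(C(=O)c1ccc(OC)cc1)C(OC(C)=O)C1CCCCC1` is not yet measured; it carries cyclohexyl in place of 2-fluorophenyl on a saturated chain carbon bound to a double-bonded chain carbon and an oxygen next to a carbonyl group. Among the compounds with values here, no measured step of this kind exists in the set. A weakening beyond the scatter is expected, with a real chance that this assay returns only a limit, because the limit of > 100000 nM in this assay, at which 1 of the 3 values shown sits, is where compound 2 already sits. The expected step is a 2.8-fold higher number from compound 3 to compound 4 (0.44 log units; beyond the scatter). Compound 4 is estimated at 50000 nM, with a range from 15000 nM to 150000 nM.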

Compound 4, half-maximal inhibitory concentration: 14000 nM
Estimate against measurement, compound 4: 3.6-fold (0.55 log units) above, and the stated range ends above it.
By their numbers in this assay, from the lowest: compounds 1, 4 and 3 (each within the scatter of the next). At a limit, above all of these: compound 2.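

In this assay, the saturated chain carbon bound to a double-bonded chain carbon and an oxygen next to a carbonyl group accepts either ring: cyclohexyl in place of 2-fluorophenyl gives a 1.3-fold lower number from compound 3 to compound 4 (0.11 log units; within the scatter). An aromatic ring at this position is therefore not required to keep this level of inhibition, at least for this pair. Cyclohexyl here does not by itself lead to a limit, and compound 2 alone stands at one: the limit of > 100000 nM in this assay, at which 1 of the 4 values shown sits.

Still open, going by these compounds, is whether a ring is needed at all at this position, which a longer chain in its place would test. An amine or a carboxylic acid on the cyclohexyl ring would show how much change this position accepts.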